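From 3-bromopropyl to 4-bromobutyl on a shared core

The compounds below may be only part of what the source reports. "The series", "measured", "known", "first", "only" and "open" are said of these compounds alone.

Measured so far in a functional assay on ECa-109 cells for inhibition, with ECa-109 cell line (Homo sapiens) as the target, read by MTT assay, with a stated time of 48 h; a lower number here means a stronger inhibitor, a higher number a weaker inhibitor
- compound 1 `COc1ccc(-c2coc3cc(OCCCBr)ccc3c2=O)cc1` gives 39700 nM
- compound 2 `COc1ccc(-c2coc3cc(OCCCCSC(=S)N4CCN(C(=O)OC(C)(C)C)CC4)ccc3c2=O)cc1` gives 8840 nM
- compound 3 `COc1ccc(-c2coc3cc(OCCCSC(=S)N4CCCC4)ccc3c2=O)cc1` gives 30800 nM

Compound 1 and compound 3 sit together at the top of this small set, within the scatter of each other, while compound 2 gives a clearly lower number. Compound 4 `COc1ccc(-c2coc3cc(OCCCCBr)ccc3c2=O)cc1` keeps the core of compound 1 and alters only the end of the chain: bromomethyl in place of bromo on a saturated chain carbon, three bonds along the chain from an oxygen on an aromatic ring. Put simply, 3-bromopropyl becomes 4-bromobutyl, and the bromine stays.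

Among the measured compounds shown here, only one measured step touches this same place. That step, a 1.3-fold lower number from compound 1 to compound 3 (0.11 log units; within the scatter), swaps the bromo for a far larger group, and the number barely moves. Compound 2 at 8840 nM carries the longer chain of compound 4, which hints at a lower number. However, compound 2 also ends in a different group, so it cannot show what the chain alone does. For the measured compounds named here, no measured pair isolates the chain length.

A small change is therefore the reasonable expectation, perhaps slightly downward and probably not beyond the scatter. The expected step is a 1.4-fold lower number from compound 1 to compound 4 (0.15 log units; within the scatter) in this assay and could fall in either direction. The estimated value for compound 4 is 28000 nM with 12000 nM to 60000 nM as the expected range.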

Compound 4, half-maximal inhibitory concentration: 66300 nM
Compound 4: middle estimate off by 2.4-fold (0.37 log units), on the low side, outside the stated range (above it).
By their numbers in this assay, from the lowest: compound 2; then compounds 3, 1 and 4 (each within the scatter of the next, the first and the last beyond it).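

In this assay, among the compounds shown here, going from 3-bromopropyl to 4-bromobutyl with the bromine kept gives the first direct reading of chain length alone, and that step, a 1.7-fold higher number from compound 1 to compound 4 (0.22 log units; within the scatter), does not separate the two compounds. The longer chain alone therefore brings no lower number here: compound 4 ends in bromine, while compound 2, with the same chain and a different end group, gives 8840 nM, and the step of a 2.2-fold higher number from compound 3 to compound 4 (0.33 log units; beyond the scatter) is a modest one that changes both the chain and its end group. Nothing measured here speaks to the cause of these differences.

Still open, from the compounds shown here alone, is whether the end group of compound 2 would give a similarly low number on the shorter chain of compound 1, and whether the end group of compound 3 would behave differently on the longer chain of compound 4. Also open, going by these compounds, is how a 2-bromoethyl chain, a chain longer than 4-bromobutyl, or an amine in place of the bromine would read in this assay.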